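This account rests on a few compounds, and the source may have more. Where it says the series, first, only, none or still open, it means among the compounds named here.

Values in a functional assay for inhibition, with Homo sapiens as the target; a lower number here means a stronger inhibitor, a higher number a weaker inhibitor:

- compound 1 `Cc1cn(-c2ccc(Nc3nccc(-c4ccncc4)n3)cc2)cn1`: > 3000 nM (a limit of the assay, not a number)
- compound 2 `c1ccc(-c2ccnc(Nc3ccc(-n4ccnc4)cc3)n2)nc1`: 1400 nM
- compound 3 `c1coc(-c2ccnc(Nc3ccc(-n4ccnc4)cc3)n2)c1`: 2200 nM

Among the measured compounds shown here, compound 3 holds one of only two numeric values, and its sole measured step lies within the scatter. That step is a 1.6-fold higher number from compound 2 to compound 3 (0.20 log units; within the scatter). Compound 1 stands at the limit of > 3000 nM in this assay, at which 1 of the 3 values shown sits.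

Compound 4 `c1cc(-c2ccnc(Nc3ccc(-n4ccnc4)cc3)n2)ccn1` carries pyridin-4-yl in place of furan-2-yl on an aromatic carbon. For the measured compounds named here, the one measured step that bears on this is the exchange of one aromatic ring for another, a 1.6-fold higher number from compound 2 to compound 3 (0.20 log units; within the scatter). A similar exchange is therefore expected to give no clear change in this assay, and no direction is favoured. The expected step is a 1.2-fold lower number from compound 3 to compound 4 (0.06 log units; within the scatter). For compound 4 the estimated value is 1900 nM, with an expected range from 800 nM to 4500 nM.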

Compound 4, half-maximal inhibitory concentration: 7600 nM
Beside the measured number, compound 4's estimate is 4.0-fold (0.60 log units) below it; the measured number lies above the stated range.
By their numbers in this assay, from the lowest: compounds 2 and 3 (each within the scatter of the next); then compound 4.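

The position on the shared core is not indifferent to which aromatic ring it carries: in this assay, pyridin-4-yl gives a 3.5-fold higher number from compound 3 to compound 4 (0.54 log units; beyond the scatter) and a 5.4-fold higher number from compound 2 to compound 4 (0.73 log units; beyond the scatter), both beyond the scatter, whereas the earlier exchange stayed within it. The two pyridines thus differ, so the place of the ring nitrogen matters here, not just the presence of a six-membered ring. The step from compound 1 to compound 4 cannot be read, as compound 1 stands at a limit of the assay: the limit of > 3000 nM in this assay, at which 1 of the 4 values shown sits.

On these data alone, whether pyridin-3-yl or a plain phenyl ring would track compound 2 or compound 4 remains open. So does the effect of an amine such as morpholine at this position.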